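Dropping a Fluoro from a Slow-Cleared Sulfone

This account rests on a few compounds, and the source may have more. Where it says the series, first, only, none or still open, it means among the compounds named here.

Among the measured compounds shown here, compound 1, `O=S(=O)(c1ccc(F)cc1)c1cnc2cc(F)c(Cl)cc2c1-c1ccc(Cl)cc1`, is one of two compounds measured in an ADME assay on microsomes from liver (Homo sapiens) for metabolic stability, tested at 2.5 uM; on this read-out lower numbers stand for slow clearance and higher numbers for fast clearance. In this assay compound 1 gives 0.01 mL/min, the lowest of the two numbers. The other measured compound is compound 2, `COc1cccc(-c2c(S(=O)(=O)c3ccc(C)c(C)c3)cnc3cc(F)ccc23)c1`, and in this assay compound 2 gives 8.78 mL/min, a number that lies far beyond the scatter above that of compound 1. Compound 2 differs from compound 1 in several places at once, so no single change can be read from the pair.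

Compound 3, `O=S(=O)(c1ccc(F)cc1)c1cnc2ccc(Cl)cc2c1-c1ccc(Cl)cc1`, has not yet been measured. It keeps the core of compound 1 and differs from it in one place: hydrogen in place of fluoro on an aromatic carbon. For the measured compounds named here, no measured pair in this set shows what such a change does, so the expectation rests only on the value of compound 1 and on the general run of these readings. The step from compound 1 to compound 3 in this assay is expected to be a 3.0-fold higher number from compound 1 to compound 3 (0.48 log units; beyond the scatter), most likely a small rise that may stay within the scatter. Compound 3 is therefore expected to give about 0.03 mL/min, with a range from 0.005 mL/min to 0.2 mL/min.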

Compound 3, intrinsic clearance in a liver preparation (reported as CLH), per the amount of preparation that the assay uses: 0.01 mL/min
Compound 3: middle estimate off by 3.0-fold (0.48 log units), on the high side; the range from low to high includes it.
By their numbers in this assay, from the lowest: compounds 1 and 3 (each within the scatter of the next); then compound 2.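

In this assay, among the compounds shown here, the swap of hydrogen in place of fluoro on an aromatic carbon gives no change at the digits printed from compound 1 to compound 3 (within the scatter) and so provides the first reading in this set of a change in one place. At this position, ortho to a chloro group and para to a fused ring, the low number seen for compound 1 does not depend on the fluoro, since compound 3 reads the same without it. This holds for this one pair on the shared core and says nothing yet about the effect of the same swap elsewhere on the core. Nothing measured here bears on why the two compounds read alike.

The compounds shown leave open whether a larger group at this same position, such as an amine or a nitrile, would also leave the number in this assay undisturbed. For the compounds shown here, they also leave open whether removing the chloro group from the core of compound 3 would shift that number, or whether it too could go with no visible step.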